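The compounds below may be only part of what the source reports. "The series", "measured", "known", "first", "only" and "open" are said of these compounds alone.

In a functional assay on SK-MEL-5 cells (Homo sapiens) for antiproliferative activity, read by sulforhodamine B assay, with a stated time of 48 h (on this read-out lower numbers stand for stronger inhibition and higher numbers for weaker inhibition), three compounds of one family have been measured. Compound 1 `COc1cc(-c2nn(-c3ccc(NC(=O)Nc4ccc(Cl)c(C(F)(F)F)c4)cc3)cc2-c2ccncc2)ccc1Cl` gives 1570 nM. Compound 2 `COc1cc(-c2nn(-c3ccc(NC(=O)c4cc(Cl)cc(Cl)c4)cc3)cc2-c2ccncc2)ccc1Cl` gives 12000 nM; this is a 7.6-fold higher number from compound 1 to compound 2 (0.88 log units; beyond the scatter). Compound 3 `O=C(Nc1ccc(-n2cc(-c3ccncc3)c(-c3ccc(Cl)c(O)c3)n2)cc1)Nc1ccc(Cl)c(C(F)(F)F)c1` gives 1530 nM, which is a 1.0-fold lower number from compound 1 to compound 3 (0.01 log units; within the scatter). On these numbers compound 3 holds the lowest value of the three, but its gap to compound 1 lies within the scatter, so the two cannot be ranked against each other; only compound 2 stands clearly apart.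

Compound 4 `O=C(Nc1ccc(-n2cc(-c3ccncc3)c(-c3ccc(Cl)c(O)c3)n2)cc1)c1cc(Cl)cc(Cl)c1` has not yet been measured. It differs from compound 3 in one place: 3,5-dichlorophenyl in place of (4-chloro-3-(trifluoromethyl)phenyl)amino on a carbonyl carbon. The same exchange has already been seen once, in the step from compound 1 to compound 2, where the number rose well beyond the scatter. The change from compound 1 to compound 3, a hydroxyl in place of a methoxy group, left the number essentially unchanged, so that part of the structure gives no reason to expect the exchange to behave differently here. The expected step is therefore a 7.2-fold higher number from compound 3 to compound 4 (0.86 log units; beyond the scatter), a rise of about the size seen from compound 1 to compound 2. For compound 4 the estimated value in this assay is 11000 nM, with a range from 4000 nM to 30000 nM.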

Compound 4, half-maximal inhibitory concentration: 1400 nM
Compound 4: the middle estimate sits 7.9-fold (0.90 log units) above what was measured, outside the stated range (below it).
By their numbers in this assay, from the lowest: compounds 4, 3 and 1 (each within the scatter of the next); then compound 2.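

In this assay the exchange on the carbonyl carbon has no single size: its effect depends on what the oxygen on the aromatic ring carries, and with hydrogen on that oxygen it gives a 1.1-fold lower number from compound 3 to compound 4 (0.04 log units; within the scatter). Set against the same exchange with methyl on that oxygen, the two steps do not agree: the same change on two cores in this assay, a 7.6-fold higher number (0.88 log units; beyond the scatter) from compound 1 to compound 2 and a 1.1-fold lower number (0.04 log units; within the scatter) from compound 3 to compound 4, 8.4-fold (0.92 log units) apart, beyond the scatter of two such steps

Read the other way, in these four compounds hydrogen in place of methyl shifts the number only when 3,5-dichlorophenyl sits on the carbonyl carbon, where it gives an 8.6-fold lower number from compound 2 to compound 4 (0.93 log units; beyond the scatter), so the two places do not act independently and their effects cannot simply be added: the same change on two cores in this assay, a 1.0-fold lower number (0.01 log units; within the scatter) from compound 1 to compound 3 and an 8.6-fold lower number (0.93 log units; beyond the scatter) from compound 2 to compound 4, 8.4-fold (0.92 log units) apart, beyond the scatter of two such steps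

These four compounds show this dependence only once, and they do not tell what lies behind it. On these data alone, whether it would persist with a longer chain such as ethyl on that oxygen, with an amine in place of the hydroxyl, or with a different aromatic group such as a 3,5-difluorophenyl on the carbonyl carbon remains open.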